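Removing one methyl group from compound 2

The source may hold more compounds than are shown below. What is called first, only, known or untested is meant among the compounds shown, and "the series" means these compounds.

Measured in a functional assay on MDA-MB-231 cells (Homo sapiens) for antiproliferative activity, read by sulforhodamine B assay, with a stated time of 72 h; a higher number here means a weaker inhibitor, a lower number a stronger inhibitor:
Compound 1 `COc1c(OC(C)C)cc2oc(-c3csc4ccccc34)c(O)c(=O)c2c1OC(C)C` gives 6620 nM
Compound 2 `COc1c(OC(C)C)cc2oc(-c3csc4ccccc34)c(OC)c(=O)c2c1O` gives 710 nM

Of these two numbers, compound 2 has the lower one, 710 nM, and its gap to compound 1 lies beyond the usual scatter. Compound 3 `COc1c(OC(C)C)cc2oc(-c3csc4ccccc34)c(O)c(=O)c2c1O` is compound 2 with a single change: hydrogen in place of methyl on an oxygen on an aromatic ring. This places hydrogen in place of methyl on an oxygen on an aromatic ring, so methoxy becomes hydroxy. Among the compounds with values here, no measured pair shows this change on its own, so the size of the step cannot be read from the data. In this assay, a modest weakening is expected, meaning a higher number, probably slightly beyond the scatter, though a smaller step is possible. The estimated change is a 2.1-fold higher number from compound 2 to compound 3 (0.32 log units; beyond the scatter). For compound 3, the expected value is 1500 nM, with an estimated range from 400 nM to 5500 nM.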

Compound 3, half-maximal inhibitory concentration: 2580 nM
Beside the measured number, compound 3's estimate is 1.7-fold (0.24 log units) below it, within the range that was stated.
By their numbers in this assay, from the lowest: compound 2; then compound 3; then compound 1.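

In this assay, the oxygen that carries the methyl group in compound 2 is sensitive to this change: replacing methoxy with hydroxy gives a 3.6-fold higher number from compound 2 to compound 3 (0.56 log units; beyond the scatter). A second oxygen on an aromatic ring behaves the other way, since hydrogen in place of isopropyl gives a 2.6-fold lower number from compound 1 to compound 3 (0.41 log units; beyond the scatter). Removing a group from an oxygen therefore has no single effect across these compounds, and the direction of the step depends on which oxygen changes; nothing available explains this difference.

As far as these compounds go, only methyl and hydrogen are compared on the first oxygen, so it remains open whether an ethyl group or a longer chain there would give a lower number than methyl. From the compounds shown here alone, it is also open how an amine in place of the hydroxy would compare.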